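Removing the benzyl from the ring nitrogen of compound 3

A few compounds are considered here, and "the series" means these few. Any claim that something is new, unique, unknown or untested is made for them only; others in the source may bear on it.

Compound 1 `Nc1n/c(=N\CCCCc2ccccc2)nc(N)c2c1ncn2Cc1ccccc1`: in a functional assay on PC-3 cells (Homo sapiens) for antiproliferative activity, read by WST assay, with a stated time of 72 h (a higher number here means a weaker inhibitor, a lower number a stronger inhibitor), compound 1 gives a limit of > 75000 nM.
Compound 2 `CCCCCCCCCCCCCC/N=c1\nc(N)c2ncn(Cc3ccccc3)c2c(N)n1`: in this assay compound 2 gives 4200 nM.
Compound 3 `CCCCCCCC/N=c1\nc(N)c2ncn(Cc3ccccc3)c2c(N)n1`: in this assay compound 3 gives 5930 nM.

Compound 3 gives the higher of the two numbers that are numbers rather than limits, but the gap to compound 2 is small: a 1.4-fold higher number from compound 2 to compound 3 (0.15 log units; within the scatter). The value of compound 1 is a limit of this assay, as stated in the limit of > 75000 nM in this assay, at which 1 of the 3 values shown sits. Against it, the two chain extensions stand out as large steps, an at least 17-fold lower number from compound 1 to compound 2 (1.25 log units; beyond the scatter) and an at least 12-fold lower number from compound 1 to compound 3 (1.10 log units; beyond the scatter).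

Compound 4 `CCCCCCCC/N=c1\nc(N)c2nc[nH]c2c(N)n1` differs from compound 3 at a different place: hydrogen in place of benzyl on an aromatic nitrogen. Within the data shown here, none of the measured steps touches the aromatic nitrogen; all of them change the end of the chain that hangs from the double-bonded nitrogen. Among the measured compounds shown here, there is therefore no measured step that bears directly on this change, and the size and direction of the step in this assay cannot be read off the three compounds above. Compound 4 is expected to give a number within the same broad range as compound 3, with the step from one to the other estimated as a 2.5-fold higher number from compound 3 to compound 4 (0.40 log units; beyond the scatter). For compound 4 the estimate in this assay is 15000 nM, with a range from 4000 nM to 60000 nM.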

Compound 4, half-maximal inhibitory concentration: "not active" (no number reported)
For compound 4 the study gives words and no number, so the estimate cannot be set against anything.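

In this assay, among these compounds, compound 4 is reported only in words, as "not active", with no number, so no step from compound 3 to compound 4 can be read. Nothing shown accounts for this result. The compounds shown leave open how large the change is when hydrogen replaces benzyl on the aromatic nitrogen.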